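Bis(trifluoromethyl)benzenesulfonamide amines on pancreatic cell growth

The source may hold more compounds than are shown below. What is called first, only, known or untested is meant among the compounds shown, and "the series" means these compounds.

Measured so far:
compound 1, `O=S(=O)(NCCNCc1cccc2ccccc12)c1cc(C(F)(F)F)cc(C(F)(F)F)c1`, 23000 nM
compound 2, `O=S(=O)(NCCCNCc1ccccc1Cl)c1cc(C(F)(F)F)cc(C(F)(F)F)c1`, 11000 nM

In a functional assay on BXPC-3 cells (Homo sapiens) for inhibition, read by MTT assay, with a stated time of 72 h (on this read-out lower numbers stand for stronger inhibition of growth and higher numbers for weaker inhibition of growth), compound 2 gives the lower of the two numbers; compound 1 gives 23000 nM, beyond the scatter above it. Compound 3, `CC(C)(C)c1ccc(CNCCCNS(=O)(=O)c2cc(C(F)(F)F)cc(C(F)(F)F)c2)cc1`, is not yet measured. It differs from compound 2 by 4-(tert-butyl)phenyl in place of 2-chlorophenyl on a saturated chain carbon bound to an amine nitrogen. Within the data shown here, no measured pair shows this change, so the step is expected to be small: a 1.2-fold lower number from compound 2 to compound 3 (0.09 log units; within the scatter), not clearly beyond the scatter in either direction. For compound 3 the estimate in this assay is 9000 nM, with a range from 3000 nM to 30000 nM.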

Compound 3, concentration for 50% growth inhibition: 1400 nM
For compound 3 the middle estimate is 6.4-fold (0.81 log units) above the measured one; the whole stated range lies above it.
By their numbers in this assay, from the lowest: compound 3; then compound 2; then compound 1.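

In this assay, the group on a saturated chain carbon bound to an amine nitrogen can shift growth inhibition beyond the scatter: 4-(tert-butyl)phenyl in place of 2-chlorophenyl gives a 7.9-fold lower number from compound 2 to compound 3 (0.90 log units; beyond the scatter). Among these compounds, this is the first comparison that differs in one place, and it marks this position as responsive to change. Nothing measured here accounts for the step.

Among the compounds shown here, the single step does not separate the loss of the chlorine from the gain of the tert-butyl group. Also open, from the compounds shown here alone, is how an unsubstituted phenyl or a phenyl bearing a carboxylic acid would stand at this place.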